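An Ethyl Group on the Acid Carbon of Compound 1

A few compounds are considered here, and "the series" means these few. Any claim that something is new, unique, unknown or untested is made for them only; others in the source may bear on it.

Three acids have been tested in a functional assay on the whole organism for inhibition, with Rattus norvegicus as the target; on this read-out higher numbers stand for an effect only at larger amounts of compound and lower numbers for an effect already at smaller amounts. Compound 1 `CC(C)c1ccc(OC(Cc2ccc(Cl)cc2)C(=O)O)cc1` gives 10 mg/kg. Compound 2 `Cc1cccc(CC(C)(Oc2ccc(C(C)C)cc2)C(=O)O)c1` reaches only a limit of the assay, < 1 mg/kg. Compound 3 `CCCc1cccc(CC(C)(Oc2ccc(C(C)C)cc2)C(=O)O)c1` gives 1 mg/kg. Compound 1 thus stands highest of the two numbers, with a gap to compound 3 beyond the scatter; how its core differs from that of compound 2 is not broken down here. The step of a number no lower from compound 2 to compound 3 (the limit leaves the size open) is ethyl in place of hydrogen on a saturated chain carbon bound to an aromatic carbon. Compound 4 `CCC(Cc1ccc(Cl)cc1)(Oc1ccc(C(C)C)cc1)C(=O)O`, not yet measured, carries ethyl in place of hydrogen on a saturated chain carbon bound to a carbonyl carbon, an oxygen on an aromatic ring and a saturated chain carbon, the same kind of change but at a different place, the saturated chain carbon bound to a carbonyl carbon, an oxygen on an aromatic ring and a saturated chain carbon. Compound 3, which bears a methyl on that same carbon, gives 1 mg/kg, and this supports an expectation that compound 4 falls under compound 1. Compound 4 is therefore expected near 3 mg/kg, from 0.8 mg/kg to 12 mg/kg, an estimated step of a 3.3-fold lower number from compound 1 to compound 4 (0.52 log units; beyond the scatter).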

Compound 4, dose for half-maximal effect: > 5 mg/kg
Compound 4: no number, only a limit; the forecaster's own chance of this, stated with the estimate: 20%; middle value at least 1.6-fold (0.22 log units) away from the limit.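

Compound 4 reaches only a limit of the assay, > 5 mg/kg, and its step from compound 1 cannot be read. The compounds shown leave open whether the ethyl group changes the number of compound 1, and by how much.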